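The source may hold more compounds than are shown below. What is called first, only, known or untested is meant among the compounds shown, and "the series" means these compounds.

Three compounds have been measured in a functional assay on MCF7 cells (Homo sapiens) for antiproliferative activity, read by CCK-8 assay, with a stated time of 72 h; a higher number here means a weaker inhibitor, a lower number a stronger inhibitor:
compound 1 `O=C(Nc1cccc(-c2oc3cc(-c4ccc(F)cc4)ccc3c(=O)c2O)c1)c1ccccc1F` gives 7570 nM;
compound 2 `O=C(Nc1cccc(-c2oc3cc(-c4ccc(F)cc4)ccc3c(=O)c2O)c1)c1ccc(C(F)(F)F)cc1` gives 32600 nM;
compound 3 `Cc1cccc(C(=O)Nc2cccc(-c3oc4cc(-c5ccc(F)cc5)ccc4c(=O)c3O)c2)c1` gives 7850 nM.

Compound 1 holds the lowest number of the three. One neighbour lies within the scatter, a 1.0-fold higher number from compound 1 to compound 3 (0.02 log units; within the scatter), while the other stands apart, a 4.3-fold higher number from compound 1 to compound 2 (0.63 log units; beyond the scatter). The untested compound 4 `CCc1ccc(C(=O)Nc2cccc(-c3oc4cc(-c5ccc(F)cc5)ccc4c(=O)c3O)c2)cc1` differs from compound 1 at the group on the carbonyl carbon: 4-ethylphenyl in place of 2-fluorophenyl on a carbonyl carbon. Both measured steps from compound 1 alter this same group. Moving to 3-methylphenyl left the number unchanged, whereas moving to 4-(trifluoromethyl)phenyl raised it modestly. A 4-ethylphenyl group is a third variation at the same place, and a small to modest rise is expected, a 1.6-fold higher number from compound 1 to compound 4 (0.20 log units; within the scatter). Compound 4 is therefore estimated at 12000 nM, between 5000 nM and 30000 nM.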

Compound 4, half-maximal inhibitory concentration: 22800 nM
Estimate against measurement, compound 4: 1.9-fold (0.28 log units) below; low and high end bracket the measured number.
By their numbers in this assay, from the lowest: compounds 1 and 3 (each within the scatter of the next); then compounds 4 and 2 (each within the scatter of the next).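

A second group carrying its substituent as a 4-phenyl name also gives a weaker compound than the two earlier leaders in this assay: 4-ethylphenyl gives a 3.0-fold higher number from compound 1 to compound 4 (0.48 log units; beyond the scatter) and a 2.9-fold higher number from compound 3 to compound 4 (0.46 log units; beyond the scatter). Fluorine is therefore not needed for this loss, since ethyl and trifluoromethyl sit within the scatter of each other (a 1.4-fold lower number from compound 2 to compound 4 (0.16 log units; within the scatter)). No measurement here explains why.

As far as these compounds go, how a 4-fluorophenyl, a 2-methylphenyl or a 4-aminophenyl group would fare on this carbonyl carbon stays open. The place on the ring and the kind of group therefore cannot yet be told apart.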